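The source may report more compounds than this note shows. Statements on the series, on what has been measured and on what is new or still open speak of the compounds shown alone.

Of the compounds shown here, two with the same core have been tested so far. Compound 1 `Cn1c(-c2ccc(NC(=O)CSc3nc4ccccc4o3)cc2)nc(-c2ccccc2)c1-c1ccccc1` gives 44.9% in a functional assay on HT-29 cells (Homo sapiens) for cytotoxicity, read by MTT assay, with a stated time of 24 h, tested at 6.4 ug/mL; on this read-out higher numbers stand for a stronger effect at the one concentration tested and lower numbers for a weaker effect. Compound 2 `Cn1cnnc1SCC(=O)Nc1ccc(-c2nc(-c3ccccc3)c(-c3ccccc3)n2C)cc1` gives 43.1% in this assay. Going by the values given here, the only measured step, a number 1.8 percentage points lower from compound 1 to compound 2 (within the scatter), means compound 2 cannot be told apart from compound 1: the two numbers sit together within the usual spread of repeated tests.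

Compound 3 `CN1CCN(CC(=O)Nc2ccc(-c3nc(-c4ccccc4)c(-c4ccccc4)n3C)cc2)CC1` has not yet been measured. It differs from compound 2 in one place: 4-methylpiperazin-1-yl in place of (4-methyl-4H-1,2,4-triazol-3-yl)sulfanyl on a saturated chain carbon bound to a carbonyl carbon. Among the compounds with values here, the measured step swaps one aromatic ring for another while the sulfur stays; here the sulfur leaves as well and a non-aromatic ring enters, so no measured step covers this change directly. That one step was within the scatter, and nothing here points to a shift in either direction. For compound 3 a result near 40% is expected, with a range from 25% to 55%. The expected step is a number 3.1 percentage points lower from compound 2 to compound 3 (within the scatter).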

Compound 3, a percentage reported as activity, at one concentration (the size of the read-out at that concentration, not a potency): 28.8%
Beside the measured number, compound 3's estimate is 11.2 percentage points above it, and the stated range covers the measured number.
By their numbers in this assay, from the lowest: compound 3; then compounds 2 and 1 (each within the scatter of the next).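

Compound 1 and compound 2 showed that one sulfur-linked aromatic ring can stand in for another with no readable difference in this assay, but that does not hold for every group at this position. Putting 4-methylpiperazin-1-yl on the saturated chain carbon bound to a carbonyl carbon gives a number 14.3 percentage points lower from compound 2 to compound 3 (beyond the scatter) and a number 16.1 percentage points lower from compound 1 to compound 3 (beyond the scatter) in the two steps, so the group here does bear on this read-out. This change removes the sulfur and the aromatic ring together, and the compounds shown cannot separate the part each one plays.

Nothing at hand explains why the number falls with this change. Also open, going by these compounds, is what a sulfur-linked piperidine ring or an open-chain dimethylamino group would give on the same carbon.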